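One Stereocentre Inverted in Compound 3

The source may hold more compounds than are shown below. What is called first, only, known or untested is meant among the compounds shown, and "the series" means these compounds.

In a functional assay on SH-SY5Y cells (Homo sapiens) for cytotoxicity, read by MTT assay, with a stated time of 72 h (on this read-out higher numbers stand for weaker inhibition and lower numbers for stronger inhibition), compound 1 `O=C1c2c[n+]([O-])c3ccccc3c2C(=O)c2c1c1ccccc1n2Cc1cn([C@@H]2C[C@H](O)[C@@H](CO)O2)nn1` gives 150 nM. Compound 2 `O=C1c2c[n+]([O-])c3ccccc3c2C(=O)c2c1c1ccccc1n2Cc1cn(CC(O)CO)nn1` is reported only as a limit, > 1000 nM. Compound 3 `CC1(C)OC[C@H](Cn2cc(Cn3c4c(c5ccccc53)C(=O)c3c[n+]([O-])c5ccccc5c3C4=O)nn2)O1` gives 820 nM, the higher of the two actual numbers, and the gap is a 5.5-fold higher number from compound 1 to compound 3 (0.74 log units; beyond the scatter).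

Compound 4 `CC1(C)OC[C@@H](Cn2cc(Cn3c4c(c5ccccc53)C(=O)c3c[n+]([O-])c5ccccc5c3C4=O)nn2)O1` differs from compound 3 in one respect: the two compounds have the same atoms and bonds and differ only in configuration as drawn: 1 of 1 stereo elements differ; a stereocentre at a saturated ring carbon is drawn S in compound 3 and R in compound 4. The atoms and bonds stay the same.

Two other measured steps also touch this part of the series: an at least 6.6-fold higher number from compound 1 to compound 2 (0.82 log units; beyond the scatter), and an at least 1.2-fold lower number from compound 2 to compound 3 (0.08 log units; that floor lies within the scatter). Like the gap above, these steps exchange or alter the group on the aromatic nitrogen, and none of them changes configuration alone. They therefore give no direct size for this inversion, and the closest comparison is the floor between the two side chains that stays within the scatter. No change beyond the scatter is expected, and the expected outcome is a 1.0-fold lower number from compound 3 to compound 4 (0.01 log units; within the scatter). Compound 4 is estimated at 800 nM, with an expected range of 400 nM to 1600 nM.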

Compound 4, half-maximal inhibitory concentration: > 1000 nM
Compound 4 gave a limit, no number; the forecaster's own chance of this, stated with the estimate: 25%; at least 1.2-fold (0.09 log units) between middle value and limit.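

Compound 4 is reported only as a limit in this assay, > 1000 nM. Inverting the stereocentre at the saturated ring carbon gives an at least 1.2-fold higher number from compound 3 to compound 4 (0.08 log units; that floor lies within the scatter), so this first comparison of the two configurations fixes no size for the change, and the step from compound 2 to compound 4 joins two limits and cannot be read: the limit of > 1000 nM in this assay, at which 2 of the 4 values shown sit. With the stereocentre drawn either way, the (2,2-dimethyl-1,3-dioxolan-4-yl)methyl group stays apart from the 4-hydroxy-5-(hydroxymethyl)oxolan-2-yl group of compound 1, with a 5.5-fold higher number from compound 1 to compound 3 (0.74 log units; beyond the scatter) and an at least 6.6-fold higher number from compound 1 to compound 4 (0.82 log units; beyond the scatter).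

As far as these compounds go, how far compound 4 actually lies from compound 3 remains open, although any gap between them could be assigned to configuration alone: the fact that compounds 3 and 4 differ only in the configuration as drawn. Also open, from the compounds shown here alone, is how a side chain ending in an amine or a carboxylic acid on the aromatic nitrogen would compare with these groups.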